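This account rests on a few compounds, and the source may have more. Where it says the series, first, only, none or still open, it means among the compounds named here.

Measured so far:
- Compound 1 `CC(C)Oc1ccc(/N=c2\[nH]c(=O)n(C[C@@H](C)C(=O)O)c(=O)n2Cc2ccc(Cl)cc2)cc1Cl`: 108%
- Compound 2 `C[C@@H](Cn1c(=O)[nH]/c(=N\c2ccc(Oc3nccs3)cc2)n(Cc2ccc(Cl)cc2)c1=O)C(=O)O`: 41.4%
- Compound 3 `CC(C)Oc1ccc(/N=c2\[nH]c(=O)n(C[C@@H](O)CO)c(=O)n2Cc2ccc(Cl)cc2)cc1Cl`: 63%

In an ADME assay on the whole organism (Rattus norvegicus) for pharmacokinetics, using cassette dosing, at a dose of 1 mg/kg by the oral route (a lower number here means that a smaller share of the oral dose reaches the circulation, a higher number that a larger share of the oral dose reaches the circulation), compound 2 gives 41.4%, the lowest of the three numbers. Compound 4 `C[C@@H](Cn1c(=O)[nH]/c(=N\c2ccc(Oc3ccc(F)cn3)cc2)n(Cc2ccc(Cl)cc2)c1=O)C(=O)O` differs from compound 2 in one place: 5-fluoropyridin-2-yl in place of 1,3-thiazol-2-yl on an oxygen on an aromatic ring. It carries 5-fluoropyridin-2-yl in place of 1,3-thiazol-2-yl on an oxygen on an aromatic ring.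

Going by the values given here, the only measured step, a number 45 percentage points lower from compound 1 to compound 3 (beyond the scatter), is large, but it lies elsewhere on the molecule. It shows that one change can move this read-out far, yet it gives no direction here. Among the compounds with values here, no measured step touches this oxygen substituent, so no clear shift can be argued.

The expected change is small, a number 5.6 percentage points higher from compound 2 to compound 4 (within the scatter). The estimate for compound 4 is 47%, with an expected range of 25% to 75%.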

Compound 4, oral bioavailability: 82.4%
Compound 4: the middle estimate sits 35.4 percentage points below what was measured; the whole stated range lies below it.
By their numbers in this assay, from the lowest: compound 2; then compound 3; then compound 4; then compound 1.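

Going by these compounds alone, putting 5-fluoropyridin-2-yl in place of 1,3-thiazol-2-yl on this oxygen gives, in this assay, a number 41 percentage points higher from compound 2 to compound 4 (beyond the scatter) and this is the first measured step at this position. So the group on this oxygen can strongly change how much of an oral dose reaches the circulation. Nothing measured here accounts for the rise.

As far as these compounds go, whether the fluorine or the six-membered ring drives the step stays open, and a plain pyridin-2-yl or a phenyl on this oxygen would help separate the two. Also open, from the compounds shown here alone, is how 5-fluoropyridin-2-yl behaves alongside the 1,2-dihydroxyethyl chain.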